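The source may report more compounds than this note shows. Statements on the series, on what has been measured and on what is new or still open speak of the compounds shown alone.

Compound 1 `CCCCSc1nc(N)nc2c1ncn2/C=C1/CC1(CO)CO`: in an ADME assay on Akata cells (Homo sapiens) for cytotoxicity, with a stated time of 7 days (a lower number here means that less compound is tolerated, a higher number that more compound is tolerated), compound 1 gives only a limit, > 20000 nM.
Compound 2 `CCCCNc1nc(N)nc2c1ncn2/C=C1/CC1(CO)CO`: in this assay compound 2 gives only a limit, > 24000 nM.
Compound 3 `CCCCCCSc1nc(N)nc2c1ncn2/C=C1/CC1(CO)CO`: in this assay compound 3 gives only a limit, > 20000 nM.

For the measured compounds named here, compound 3 thus stands at a limit, and the two other values shown are limits as well, so no compound is placed against another. The steps a step that the two limits leave unreadable from compound 1 to compound 2, a step that the two limits leave unreadable from compound 1 to compound 3 and a step that the two limits leave unreadable from compound 2 to compound 3 are all unreadable for that reason (the limit of > 20000 nM in this assay, at which 2 of the 3 values shown sit, (the limit of > 24000 nM in this assay, at which 1 of the 3 values shown sits)).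

Compound 4 `CCCCCCOc1nc(N)nc2c1ncn2/C=C1/CC1(CO)CO` differs from compound 3 by hexyloxy in place of hexylsulfanyl on an aromatic carbon. No measured step bears on this exchange, and none of the steps shown is readable, so no step beyond the scatter is expected; the step that the limit leaves unreadable from compound 3 to compound 4 is the expectation. Compound 4 is estimated at 25000 nM, with a range from 10000 nM to 60000 nM, most likely again as a limit.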

Compound 4, half-maximal cytotoxic concentration: > 20000 nM
Compound 4 was reported as a limit; the forecaster's own chance of this, stated with the estimate: 80%; the middle value does not contradict the limit.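

Compound 4 gives only a limit in this assay, as do compound 1, compound 2 and compound 3, so no step among them can be read: the limit of > 20000 nM in this assay, at which 3 of the 4 values shown sit.

The compounds shown leave open the concentration at which any of them becomes cytotoxic, and whether the exchanges on the aromatic carbon change it.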